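This account rests on a few compounds, and the source may have more. Where it says the series, first, only, none or still open, it means among the compounds named here.

In a functional assay on A549 cells (Homo sapiens) for inhibition, read by MTT assay, with a stated time of 48 h (on this read-out higher numbers stand for weaker inhibition and lower numbers for stronger inhibition), the measured compounds stand as follows:
Compound 1 `COc1ccc2c(=O)c(/C=C/C(=O)NCc3cccc(F)c3)coc2c1` gives 26900 nM.
Compound 2 `COc1ccc2c(=O)c(/C=C/C(=O)Nc3ccc(Cl)cc3)coc2c1` gives only a limit, > 100000 nM.
Compound 3 `COc1ccc2c(=O)c(/C=C/C(=O)NCc3ccc(F)cc3)coc2c1` gives only a limit, > 100000 nM.

Within the data shown here, compound 1 therefore holds the only real number among the three, the other two values being limits (the limit of > 100000 nM in this assay, at which 2 of the 3 values shown sit). Compound 4 `CCOc1ccc(NC(=O)/C=C/c2coc3cc(OC)ccc3c2=O)cc1` has not yet been measured. It differs from compound 1 in one place: 4-ethoxyphenyl in place of 3-fluorobenzyl on an amide-type nitrogen. The step that bears on this most closely is an at least 3.7-fold higher number from compound 1 to compound 2 (0.57 log units; beyond the scatter), a change of the same kind, in which a group joined directly to the amide-type nitrogen replaced the 3-fluorobenzyl group. A step in the same direction, towards weaker inhibition, is expected here. Compound 4 is therefore estimated at 90000 nM, with a range from 30000 nM to 300000 nM, meaning an expected 3.3-fold higher number from compound 1 to compound 4 (0.52 log units; beyond the scatter), quite possibly reported only as a limit.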

Compound 4, half-maximal inhibitory concentration: > 100000 nM
Compound 4: only a limit was reported; the forecaster's own chance of this, stated with the estimate: 60%; middle value at least 1.1-fold (0.04 log units) away from the limit.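

Replacing 3-fluorobenzyl with 4-ethoxyphenyl on the amide-type nitrogen gives an at least 3.7-fold higher number from compound 1 to compound 4 (0.57 log units; beyond the scatter). Compound 4 is thus a second compound, after compound 2, with a ring joined directly to that nitrogen and no readable inhibition, though compound 3 keeps a benzyl group and also shows none. Compound 4 gives only a limit, so its steps to compound 2 and compound 3 cannot be read: the limit of > 100000 nM in this assay, at which 3 of the 4 values shown sit.

Among these compounds, compound 1 remains the only compound with a real number. On these data alone, what an unsubstituted benzyl group, or a longer chain ending in a 3-fluorophenyl ring, would give stays open.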